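This account rests on a few compounds, and the source may have more. Where it says the series, first, only, none or still open, it means among the compounds named here.

In an assay on membranes from HEK293 cells for displacement of a labelled ligand from adenosine receptor A2b (Homo sapiens), read by scintillation counting, with a stated time of 30 min, tested at 1 uM (on this read-out higher numbers stand for more inhibition at the one concentration tested (going by the name of the read-out) and lower numbers for less inhibition), three compounds of a shared core have been measured. Within the data shown here, compound 1 `CC1=C(C(=O)OCC(C)C)C(c2ccco2)NC(=O)N1C` gives 4%, and compound 2 `CC1=C(C(=O)OCC(C)C)C(c2ccoc2)NC(=O)N1C` gives 1%; the step of a number 3 percentage points lower from compound 1 to compound 2 (within the scatter) is the only single-change step available, and it concerns the heteroaryl group, not the ester. Compound 3 `COC(=O)C1=C(C)N(C)C(=O)NC1c1ccsc1` gives 26% and stands highest of the three, with compound 1 nearest and compound 2 furthest, both gaps being beyond the scatter. Compound 3, however, differs from compounds 1 and 2 in two places at once, so its values alone cannot tell which of the two changes carries the gap.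

Compound 4 `CC1=C(C(=O)OCC(C)C)C(c2ccsc2)NC(=O)N1C` is the next one to be measured. The change from compound 3 is isopropyl in place of hydrogen on a saturated chain carbon bound to an oxygen next to a carbonyl group. Among the measured compounds shown here, no measured step bears on this change: the ester has not been varied on its own among the measured compounds. What can be said is that compound 3, with its methyl ester, gives 26%, while the two isobutyl esters give 4% for compound 1 and 1% for compound 2, though their heteroaryl group differs as well. Compound 4 is therefore expected to lie between these, with an estimated step of a number 12 percentage points lower from compound 3 to compound 4 (beyond the scatter). For compound 4 the estimate is 14%, within a range from 0% to 34%.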

Compound 4, a percentage reported as inhibition, at one concentration (the size of the read-out at that concentration, not a potency): 1%
Estimate against measurement, compound 4: 13 percentage points above; the range from low to high includes it.
By their numbers in this assay, from the lowest: compounds 2, 4 and 1 (each within the scatter of the next); then compound 3.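

In this assay, the ester can now be read on its own: going from methoxycarbonyl to isobutoxycarbonyl, with the thiophen-3-yl group held in place, gives a number 25 percentage points lower from compound 3 to compound 4 (beyond the scatter) and so accounts for the gap that compound 3 showed over the isobutyl esters. Among those isobutyl esters the heteroaryl group leaves no readable mark, since thiophen-3-yl in place of furan-3-yl gives no change at the digits printed from compound 2 to compound 4 (within the scatter) and thiophen-3-yl in place of furan-2-yl gives a number 3 percentage points lower from compound 1 to compound 4 (within the scatter) on a saturated ring carbon. Nothing available here explains why this ester change goes with the lower number.

The heteroaryl comparison rests on isobutyl esters alone, so the compounds shown do not tell whether furan-2-yl or furan-3-yl would match thiophen-3-yl when the ester is methoxycarbonyl. They also leave open what lies between the two esters and beyond them, such as an ethyl or propyl ester in place of the isobutyl ester, or a free carboxylic acid or a primary amide at the same place on the shared core.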